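The compounds below may be only part of what the source reports. "The series", "measured", "known", "first", "only" and "open" are said of these compounds alone.

In an in vitro functional assay on cells for agonist activity at Bombesin receptor subtype-3 (Homo sapiens), read by luminescence and calcium flux (on this read-out higher numbers stand for an effect only at larger amounts of compound and lower numbers for an effect already at smaller amounts), compound 1, with the structure `O=C(O)c1ccccc1-c1ccc(CCc2ncc(CC3CCCCC3)[nH]2)cc1`, gives 41 nM. Of the two numbers measured in this assay, that of compound 1 is the lowest. Within the data shown here, compound 3, with the structure `CCCCc1cnc(CCCc2ccc(-c3ccccc3C(=O)O)cc2)[nH]1`, gives 5600 nM in this assay, a number that lies beyond the usual scatter above that of compound 1; no single-point step connects the two structures, so only the two values can be compared. Compound 2, with the structure `CCCCc1cnc(Cc2ccc(-c3ccccc3C(=O)O)cc2)[nH]1`, reaches only a limit of the assay, > 10000 nM, as summed up in the limit of > 10000 nM in this assay, at which 1 of the 3 values shown sits.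

Compound 4, with the structure `O=C(O)c1ccccc1-c1ccc(CCc2ncc(CC3CCCC3)[nH]2)cc1`, has not yet been measured. It differs from compound 1 in one place: cyclopentyl in place of cyclohexyl on a saturated chain carbon bound to an aromatic carbon, or, read one bond further out, cyclohexylmethyl to cyclopentylmethyl. The step from compound 1 to compound 4 in this assay is expected to be a 2.0-fold higher number from compound 1 to compound 4 (0.29 log units; within the scatter), at most a small rise. Compound 4 is thus estimated to give 80 nM, within a range from 25 nM to 300 nM.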

Compound 4, half-maximal effective concentration: 133 nM
Compound 4: middle estimate off by 1.7-fold (0.22 log units), on the low side; low and high end bracket the measured number.
By their numbers in this assay, from the lowest: compound 1; then compound 4; then compound 3. At a limit, above all of these: compound 2.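

In this assay, among these compounds, cyclopentyl in place of cyclohexyl on a saturated chain carbon bound to an aromatic carbon gives a 3.2-fold higher number from compound 1 to compound 4 (0.51 log units; beyond the scatter), the first step between measured compounds that differ in one place. It shows that this position responds to a change in ring size, although the step is modest and compound 4 still gives a measured number rather than a limit. Nothing among the measurements shown offers a reason for this step.

As far as these compounds go, a single pair cannot show whether the number would keep changing in the same direction with other ring sizes, so how a cycloheptyl ring would read at this place remains open. From the compounds shown here alone, it is equally open how a phenyl ring would read there, or a cyclohexyl ring carrying an amine.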